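The source may hold more compounds than are shown below. What is called first, only, known or untested is meant among the compounds shown, and "the series" means these compounds.

Working notes on the series. Compound 1 `Sc1nc(NCc2ccccc2)c2ccccc2n1` carries a sulfanyl group on the shared core. In a functional assay on CCRF-CEM cells (Homo sapiens) for cytotoxicity, read by MTT assay, with a stated time of 72 h (on this read-out higher numbers stand for lower toxicity in this test and lower numbers for higher toxicity in this test), compound 1 gives only a limit of the test, > 100000 nM. Compound 1 therefore sits at the limit of > 100000 nM in this assay, at which 1 of the 2 values shown sits, and no single number stands for it in this assay. Compound 2 `[SeH]c1nc([SeH])c2cccnc2n1` belongs to the same set, but in this assay compound 2 has "not determined" (no result reported), so it adds nothing to the comparison. Compound 3 `C[Se]c1nc(NCc2ccccc2)c2ccccc2n1` is the next compound for this assay. The change from compound 1 to compound 3 is a group of 2 heavy atoms (1 carbon, 1 selenium; no ring) in place of one sulfur atom, on an aromatic carbon. Within the data shown here, no step between two measured compounds is available in this assay, so the size of the step from compound 1 to compound 3 rests on expectation alone. With compound 1 at a limit, the only room for a visible change lies toward higher toxicity. In this assay compound 3 is expected to move by an at least 2.0-fold lower number from compound 1 to compound 3 (0.30 log units; that floor lies within the scatter) in that direction, a step of moderate size, though a repeat of the limit would not surprise. The estimate for compound 3 is 50000 nM, with a range from 10000 nM to 150000 nM.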

Compound 3, concentration lethal to 50% of the cells: 83500 nM
For compound 3 the middle estimate is 1.7-fold (0.22 log units) below the measured one; low and high end bracket the measured number.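

In this assay, putting the group of 2 heavy atoms (1 carbon, 1 selenium; no ring) in place of the sulfanyl group, on the aromatic carbon between two ring nitrogen atoms, gives an at least 1.1-fold lower number from compound 1 to compound 3 (0.07 log units; that floor lies within the scatter). Compound 1 stands only at a limit of the test, not at a number: the limit of > 100000 nM in this assay, at which 1 of the 3 values shown sits. Among these compounds, compound 3 gives 83500 nM, the first single number at this position. The step as printed lies within the scatter, so this one pair fixes neither the size of the step nor a real separation of the two compounds.

The compounds shown do not tell whether the selenium atom or the added carbon accounts for the single number in compound 3, and a methylsulfanyl group at the same position would be the direct comparison for that question. On these data alone, how an amine, a hydroxyl group or a longer chain on selenium would read at this aromatic carbon in this assay also remains open, as does whether any such group would give a step beyond the scatter.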